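Ethyl to methyl on the dihydroxycyclohexyl series

This account rests on a few compounds, and the source may have more. Where it says the series, first, only, none or still open, it means among the compounds named here.

Measured in an ADME assay on microsomes from liver (Homo sapiens) for metabolic stability, read by LC-MS, using NADPH, with a stated time of 30 min, tested at 1 uM; a lower number here means slower removal, a higher number faster removal of the compound:
- compound 1 `C[C@H]1C[C@@H](c2ccncc2NC(=O)c2nc(-c3ncccc3F)ccc2N)C[C@@H](O)[C@@]1(O)CF`: 8 mL/min/kg
- compound 2 `CC[C@]1(O)[C@H](O)C[C@H](c2ccncc2NC(=O)c2nc(-c3ncccc3F)ccc2N)C[C@@H]1C`: 62 mL/min/kg

Compound 2 holds the higher of the two numbers in this assay. Compound 3 `C[C@H]1C[C@@H](c2ccncc2NC(=O)c2nc(-c3ncccc3F)ccc2N)C[C@@H](O)[C@]1(C)O` differs from it by hydrogen in place of methyl on a saturated chain carbon bound to a saturated ring carbon, turning ethyl into methyl. Going by the values given here, the only measured step at this carbon is a 7.8-fold higher number from compound 1 to compound 2 (0.89 log units; beyond the scatter), beyond the scatter, and it involves fluoro rather than hydrogen. On that single precedent, a fall of similar or smaller size is expected, an estimated step of a 2.5-fold lower number from compound 2 to compound 3 (0.39 log units; beyond the scatter). The estimate for compound 3 is 25 mL/min/kg, with an expected range of 11 mL/min/kg to 50 mL/min/kg.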

Compound 3, clearance: 30 mL/min/kg
Beside the measured number, compound 3's estimate is 1.2-fold (0.08 log units) below it, and the stated range covers the measured number.
By their numbers in this assay, from the lowest: compound 1; then compound 3; then compound 2.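

In this assay, hydrogen in place of methyl on this saturated chain carbon gives a 2.1-fold lower number from compound 2 to compound 3 (0.32 log units; beyond the scatter) and so shows that the ethyl to methyl change alone moves the clearance beyond the scatter. Hydrogen in place of fluoro on the same carbon gives a 3.8-fold higher number from compound 1 to compound 3 (0.57 log units; beyond the scatter) and places the methyl compound between the other two, with the fluoro compound lowest. No measurement at hand accounts for either step.

Going by these compounds, whether a longer chain such as propyl would extend the rise from compound 3 to compound 2 stays open. So does the effect of an amine on this carbon.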